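This account rests on a few compounds, and the source may have more. Where it says the series, first, only, none or still open, it means among the compounds named here.

Of the compounds shown here, two have been measured in a functional assay on HeLa cells (Homo sapiens) for antiproliferative activity, read by CCK-8 assay, with a stated time of 72 h, tested at 8 uM; a lower number here means a weaker effect, a higher number a stronger effect of the compound at the concentration tested. Compound 2 `CC1CCCCN1C(=S)SCc1ccc(C(=O)Nc2ccccc2N)cc1` gives 76.3% in this assay, the higher of the two numbers. Compound 1 `Nc1ccccc1NC(=O)c1ccc(CSC(=S)N2CCN(c3cccnc3)CC2)cc1` gives 72.5% in this assay, which lies within the scatter of compound 2, so the two cannot be ordered. Compound 3 `CN(Cc1ccncc1)C(=S)SCc1ccc(C(=O)Nc2ccccc2N)cc1` has not yet been measured. It differs from compound 2 in one place: methyl((pyridin-4-yl)methyl)amino in place of 2-methylpiperidin-1-yl on a thiocarbonyl carbon. For the measured compounds named here, no step between measured compounds is available to calibrate this change, so the step of a number 6.3 percentage points lower from compound 2 to compound 3 (within the scatter) is expected to stay within the scatter. Compound 3 is therefore estimated at 70%, with a range of 55% to 82%.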

Compound 3, a percentage reported as inhibition, at one concentration (the size of the read-out at that concentration, not a potency): 72.7%
For compound 3 the middle estimate is 2.7 percentage points below the measured one; measured number inside the range.
By their numbers in this assay, from the lowest: compounds 1, 3 and 2 (each within the scatter of the next).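

On the thiocarbonyl carbon, replacing 2-methylpiperidin-1-yl with methyl((pyridin-4-yl)methyl)amino gives a number 3.6 percentage points lower from compound 2 to compound 3 (within the scatter) in this assay and so leaves the read-out unresolved from that of compound 2. At this position, therefore, a non-aromatic ring and an aromatic ring carrying a hydrogen-bond acceptor cannot be told apart at the single concentration tested. No supporting evidence bears on this result. Still open, on these data alone, is whether a phenyl group in place of the pyridin-4-yl ring would give a similar number. As far as these compounds go, a longer chain between the amine nitrogen and that ring also remains untested here.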